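The compounds below may be only part of what the source reports. "The series", "measured", "known", "first", "only" and "open" are said of these compounds alone.

Compound 1, `COC(=O)CCNC(=O)[C@@H]1O[P@@](=O)(OCOC(=O)c2ccnn2C)OCC1(C)C`: in an ADME assay on blood (Homo sapiens) for pharmacokinetics (a higher number here means that the compound lasts longer, a lower number that the compound disappears faster), compound 1 gives > 1 h, which is a limit of the assay.
Compound 2, `COC(=O)CCNC(=O)[C@@H]1O[P@](=O)(OCOC(=O)c2ccnn2C)OCC1(C)C`: in this assay compound 2 gives < 0.16 h, a limit of the assay.
Compound 3, `CC(C)(C)C(=O)OCO[P@@]1(=O)OCC(C)(C)[C@H](C(=O)NCCC(=O)OCCc2ccccn2)O1`: in this assay compound 3 gives < 0.16 h, again a limit of the assay.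

Compound 2 therefore stands at the lower limit, with no number of its own. Within the data shown here, the only measured step, an at least 6.2-fold lower number from compound 1 to compound 2 (0.79 log units; beyond the scatter), goes with the fact that compounds 1 and 2 differ only in the configuration as drawn and leaves the ester part untouched. Compound 4, `COC(=O)CCNC(=O)[C@@H]1O[P@](=O)(OCOC(=O)c2cc(C(C)(C)C)n[nH]2)OCC1(C)C`, differs from compound 2 only in that part: 3-(tert-butyl)-1H-pyrazol-5-yl in place of 1-methyl-1H-pyrazol-5-yl on a carbonyl carbon. No measured step alters this group, so nothing shown gives a size or direction for the step in this assay from this change. Because (the limit of < 0.16 h in this assay, at which 2 of the 3 values shown sit), the series as a whole sits mostly at the lower limit, and compound 4 is expected to remain there, with a step that the limit leaves unreadable from compound 2 to compound 4 not beyond the scatter. For compound 4 the estimate in this assay is 0.12 h, within 0.05 h to 0.4 h, and the assay is expected to report only a limit.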

Compound 4, half-life: < 0.16 h
Compound 4 gave a limit, no number (the forecaster's own chance of this, stated with the estimate: 70%); the middle value does not contradict the limit.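

In this assay compound 4 gives < 0.16 h, a limit of the assay. Among these compounds, compound 2 gives < 0.16 h, also a limit, and no step between compound 2 and compound 4 can be read. The compounds shown leave open how 3-(tert-butyl)-1H-pyrazol-5-yl in place of 1-methyl-1H-pyrazol-5-yl affects half-life with the phosphorus configuration of compound 1.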